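Imidazolyl to cyano on an acylguanidine sulfone core

This account rests on a few compounds, and the source may have more. Where it says the series, first, only, none or still open, it means among the compounds named here.

The series shares a core seen in compound 1 `Cc1c(C(=O)N=C(N)N)cc(S(C)(=O)=O)c(C)c1C`, which in a functional assay for inhibition of sodium/hydrogen exchanger (Oryctolagus cuniculus) (on this read-out lower numbers stand for stronger inhibition and higher numbers for weaker inhibition), gives 55 nM. Compound 2 `Cc1c(C(=O)N=C(N)N)cc(S(C)(=O)=O)c(Oc2cccnc2)c1C` gives 23 nM in this assay, while compound 3 `Cc1c(C(=O)N=C(N)N)cc(S(C)(=O)=O)c(-n2ccnc2)c1C` gives 290 nM. Compound 3 therefore stands highest of the three; the nearest is compound 1, a step of a 5.3-fold higher number from compound 1 to compound 3 (0.72 log units; beyond the scatter), and the furthest is compound 2, a step of a 13-fold higher number from compound 2 to compound 3 (1.10 log units; beyond the scatter). Compound 4 `Cc1c(C(=O)N=C(N)N)cc(S(C)(=O)=O)c(C#N)c1C` differs from compound 3 by cyano in place of 1H-imidazol-1-yl on an aromatic carbon, on an aromatic carbon of a six-membered aromatic ring of carbon only. For the measured compounds named here, no measured step introduces cyano, so the bearing steps are those that put imidazolyl in and take it out: a 5.3-fold higher number from compound 1 to compound 3 (0.72 log units; beyond the scatter), a modest rise, and a 2.4-fold lower number from compound 1 to compound 2 (0.38 log units; beyond the scatter), a modest fall for another replacement of methyl. Taking imidazolyl away is thus expected to lower the number in this assay, with compound 4 expected near compound 1, a step of a 4.8-fold lower number from compound 3 to compound 4 (0.68 log units; beyond the scatter). Compound 4 is estimated at 60 nM, with a range from 20 nM to 180 nM.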

Compound 4, half-maximal inhibitory concentration: 370 nM
The estimate for compound 4 lay 6.2-fold (0.79 log units) below the measured number; the measured number lies above the stated range.
By their numbers in this assay, from the lowest: compound 2; then compound 1; then compounds 3 and 4 (each within the scatter of the next).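

In this assay, cyano in place of 1H-imidazol-1-yl gives a 1.3-fold higher number from compound 3 to compound 4 (0.11 log units; within the scatter) and so does not separate the two groups at this position, although one is a five-membered aromatic ring and the other has no ring. Cyano in place of methyl gives a 6.7-fold higher number from compound 1 to compound 4 (0.83 log units; beyond the scatter) and cyano in place of (pyridin-3-yl)oxy gives a 16-fold higher number from compound 2 to compound 4 (1.21 log units; beyond the scatter) in the same assay, so removing the imidazolyl ring does not return the number to the level of compound 1, and compound 2 remains the only replacement of methyl here that lowers it. No measurement shown accounts for this shared rise.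

The compounds leave open whether the rise belongs to cyano and imidazolyl alone or extends to other groups on this carbon. A methoxy group, a primary amine or a carboxylic acid here would test that.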